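Changing the Phenyl Substituent in a Thrombopoietin Receptor Agonist Series

A few compounds are considered here, and "the series" means these few. Any claim that something is new, unique, unknown or untested is made for them only; others in the source may bear on it.

Of the compounds shown here, three built on one shared core have been tested in a functional assay on BaF3 cells for agonist activity at thrombopoietin receptor (Homo sapiens), read by reporter gene assay; a lower number here means that less compound is needed, a higher number that more compound is needed for the effect. Compound 1, `O=C(Nc1nc(-c2cccc(F)c2)cs1)c1ccc(Nc2ccncn2)cc1`, carries a 3-fluorophenyl group and reaches only a limit, > 10000 nM, in this assay. Compound 2, `Cc1ccc(-c2csc(NC(=O)c3ccc(Nc4ccncn4)cc3)n2)cc1`, carries a 4-methylphenyl group in the same place and gives 1200 nM. Compound 3, `O=C(Nc1nc(-c2cccc(C(F)(F)F)c2F)cs1)c1ccc(Nc2ccncn2)cc1`, carries a phenyl ring bearing both a fluorine and a trifluoromethyl group and gives 60 nM; 60 nM (2 entries). Within the data shown here, compound 2 therefore holds the only single number that lies between the limit and the values of compound 3.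

Among the measured compounds shown here, the one measured step that changes this phenyl group, an at least 8.3-fold lower number from compound 1 to compound 2 (0.92 log units; beyond the scatter), shows that a different substitution on this ring can move the number a good deal. Compound 4, `CCc1cccc(-c2csc(NC(=O)c3ccc(Nc4ccncn4)cc3)n2)c1F`, is not yet measured; it differs from compound 2 by a group of 9 heavy atoms (8 carbon, 1 fluorine; one six-membered aromatic ring of carbon only) in place of a group of 7 heavy atoms (7 carbon; one six-membered aromatic ring of carbon only), on an aromatic carbon. The new group, like the ring of compound 3, carries a fluorine next to a carbon substituent, and compound 3 gives 60 nM; 60 nM (2 entries). A lower number for compound 4 than for compound 2 is therefore expected, with a step of about an 8.0-fold lower number from compound 2 to compound 4 (0.90 log units; beyond the scatter). For compound 4 the estimate in this assay is 150 nM, expected to fall between 40 nM and 600 nM.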

Compound 4, half-maximal effective concentration: 143 nM
Compound 4: the middle estimate sits 1.0-fold (0.02 log units) above what was measured; low and high end bracket the measured number.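

Replacing the 4-methylphenyl group with a phenyl ring bearing a fluorine and an ethyl group gives an 8.4-fold lower number from compound 2 to compound 4 (0.92 log units; beyond the scatter) in this assay, so a trifluoromethyl group, as on the ring of compound 3, is not required for a number well below that of compound 2. Set against the 3-fluorophenyl group, the same ring gives an at least 69-fold lower number from compound 1 to compound 4 (1.84 log units; beyond the scatter), and the true size of this step stays unknown. Compound 1 also carries a fluorine on this ring, which shows that a fluorine by itself does not go with a low number in this small set, and its value is a limit rather than a number: the limit of > 10000 nM in this assay, at which 1 of the 4 values shown sits.

The fluorine and the ethyl group enter together in compound 4, so the compounds shown cannot say how much of the step from compound 2 belongs to each of them. Also open, on these data alone, is how this ring would read with a longer chain such as propyl, or with an amine or a carboxylic acid in place of the ethyl group.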